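The source may report more compounds than this note shows. Statements on the series, on what has been measured and on what is new or still open speak of the compounds shown alone.

Measured in a physicochemical assay for acid dissociation, so far:
compound 1 `Fc1ccc(Cc2ccc3c(NCCCNCc4ccco4)ccnc3c2)c(Cl)c1` gives 9.47
compound 2 `CC(C)(C)c1ccc(-c2ccc3c(NCCCNCc4ccco4)ccnc3c2)cc1` gives 9.47
compound 3 `Clc1ccc(Oc2ccc3c(NCCCNCc4ccco4)ccnc3c2)cc1` gives 9.28

Compound 1 stands level with compound 2 at the digits shown, the two together the highest of the three numbers; compound 3 lies furthest from it, with the step of a number 0.19 log units lower from compound 1 to compound 3 (within the scatter) within the scatter. Compound 4 `FC(F)(F)c1cccc(Cc2ccc3c(NCCCNCc4ccco4)ccnc3c2)c1` is the next member to be measured. Relative to compound 1 it carries 3-(trifluoromethyl)phenyl in place of 2-chloro-4-fluorophenyl on a saturated chain carbon bound to an aromatic carbon. The measured steps that bear on this all exchange the group on the same aromatic carbon of the shared core: no change at the digits printed from compound 1 to compound 2 (within the scatter), a number 0.19 log units lower from compound 1 to compound 3 (within the scatter) and a number 0.19 log units lower from compound 2 to compound 3 (within the scatter). Each stays within the scatter, although none of them swaps the ring inside a benzyl group as this step does. On that basis no step beyond the scatter is expected in this assay, that is a number 0.02 log units lower from compound 1 to compound 4 (within the scatter). For compound 4 the expected value in this assay is 9.45, with a range from 9.15 to 9.75.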

Compound 4, acid dissociation constant: 9.47
Compound 4: the middle estimate sits 0.02 log units below what was measured; low and high end bracket the measured number.
By their numbers in this assay, from the lowest: compounds 3, 1, 2 and 4 (each within the scatter of the next).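

In this assay, within the data shown here, the exchange of the ring inside the benzyl group shows no change at the digits printed from compound 1 to compound 4 (within the scatter), the first reading for a change made within that group, not for a replacement of the whole group on the aromatic carbon. At this position, a ring carrying trifluoromethyl and one carrying chlorine and fluorine therefore cannot be told apart in this read-out. No measurement at hand bears on the reason for this result.

Going by these compounds, it remains open whether an amine or a carboxylic acid on this ring would also stay within the scatter.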